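The compounds below may be only part of what the source reports. "The series", "measured", "known", "first", "only" and "open" are said of these compounds alone.

Measured compounds:
- compound 1, `O=C(Nc1ccc(Oc2ccnc3[nH]ccc23)cc1)c1cn(-c2ccc(F)cc2)c2ccccc2c1=O`: 720 nM
- compound 2, `O=C(Nc1ccc(Oc2ccnc3[nH]ccc23)c(F)c1)c1cn(-c2ccc(F)cc2)c2ccccc2c1=O`: 520 nM
- compound 3, `O=C(Nc1ccc(Oc2ccnc3[nH]ccc23)c(F)c1)c1cn(-c2ccc(Br)cc2)c2ccccc2c1=O`: 650 nM

All three numbers come from a functional assay on MCF7 cells (Homo sapiens) for inhibition, read by MTT assay, with a stated time of 72 h; a higher number here means a weaker inhibitor, a lower number a stronger inhibitor. Compound 2 carries the change fluoro in place of hydrogen on an aromatic carbon relative to compound 1, and the step it made is a 1.4-fold lower number from compound 1 to compound 2 (0.14 log units; within the scatter). Compound 3 differs from compound 2 by bromo in place of fluoro on an aromatic carbon, with a 1.3-fold higher number from compound 2 to compound 3 (0.10 log units; within the scatter). The difference between the cores of compound 3 and compound 1 is not broken down here.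

Compound 4, `O=C(Nc1ccc(Oc2ccnc3[nH]ccc23)c(F)c1)c1cn(-c2ccc(Br)cc2F)c2ccccc2c1=O`, is not yet measured in this assay. Relative to compound 3 it carries fluoro in place of hydrogen on an aromatic carbon. This is the same kind of change as that from compound 1 to compound 2, though the surroundings differ: in compound 2 the entering fluoro sits meta to a large group, in compound 4 meta to a bromo group (1 heavy atom), so the two are not the same change.

For the measured compounds named here, the one precedent, compound 1 to compound 2, stayed within the scatter with a 1.4-fold lower number from compound 1 to compound 2 (0.14 log units; within the scatter). On that basis a step of similar size is expected for compound 4, a 1.2-fold lower number from compound 3 to compound 4 (0.07 log units; within the scatter). Compound 4 is therefore estimated at 550 nM in this assay, with a range from 300 nM to 1000 nM.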

Compound 4, half-maximal inhibitory concentration: 1390 nM
Estimate against measurement, compound 4: 2.5-fold (0.40 log units) below; measured number outside the range, above it.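

In this assay, fluoro in place of hydrogen on an aromatic carbon, here ortho to a large group and meta to a bromo group, gives a 2.1-fold higher number from compound 3 to compound 4 (0.33 log units; beyond the scatter), and 4-bromo-2-fluorophenyl in place of 4-fluorophenyl on an aromatic nitrogen gives a 2.7-fold higher number from compound 2 to compound 4 (0.43 log units; beyond the scatter). The same replacement therefore does not carry over as one fixed step between these two cores: the same change on two cores in this assay, a 1.4-fold lower number (0.14 log units; within the scatter) from compound 1 to compound 2 and a 2.1-fold higher number (0.33 log units; beyond the scatter) from compound 3 to compound 4, 3.0-fold (0.47 log units) apart, beyond the scatter of two such steps. The two fluoro groups enter at different places as well as on different cores, and this single pair of steps does not show which of these differences separates them or how the change would behave on a further core.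

Still open, as far as these compounds go, is whether the higher number of compound 4 depends on the bromo group, which a chloro or methyl group in its place would test. Also open, from the compounds shown here alone, is whether a methoxy group or an amine at the position of the entering fluoro would give a step of similar size in this assay.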